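The source may hold more compounds than are shown below. What is called first, only, known or untested is meant among the compounds shown, and "the series" means these compounds.

Compound 2 `O=C(Nc1ccc(F)c(-c2nc3ccccc3s2)c1)c1cc([N+](=O)[O-])ccc1Cl` gives only a limit in an ADME assay on BJ cells (Homo sapiens) for cytotoxicity, with a stated time of 72 h (on this read-out lower numbers stand for an effect already at smaller amounts and higher numbers for an effect only at larger amounts of compound), its value being > 25000 nM. Compound 1 `O=C(Nc1cccc(-c2nc3ccccc3s2)c1)c1cc([N+](=O)[O-])ccc1Cl` also reaches only a limit, > 27000 nM. Compound 3 `O=C(Nc1nc2ccc(F)cc2s1)c1cc([N+](=O)[O-])ccc1Cl` likewise stops at a limit, > 27000 nM. For the measured compounds named here, the one measured change within this set, a step that the two limits leave unreadable from compound 1 to compound 2, cannot be sized because both ends rest at the limit of > 25000 nM in this assay, at which 1 of the 3 values shown sits, and (the limit of > 27000 nM in this assay, at which 2 of the 3 values shown sit). Compound 4 `COc1ccc(NC(=O)c2cc([N+](=O)[O-])ccc2Cl)cc1-c1nc2ccccc2s1` differs from compound 2 by methoxy in place of fluoro on an aromatic carbon. Going by the values given here, no measured step here involves a methoxy group, and the three limits show only that no effect was reached at the amounts tested. Compound 4 is therefore expected to give about 27000 nM, within 10000 nM to 60000 nM, an expected step that the limit leaves unreadable from compound 2 to compound 4 that stays within the scatter.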

Compound 4, half-maximal effective concentration: > 25000 nM
Compound 4 ended at the assay's limit (the forecaster's own chance of this, stated with the estimate: 85%); the middle value does not contradict the limit.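

Compound 1, compound 2 and compound 4 all stop at limits in this assay, so the steps leading to compound 4 cannot be read. The compounds shown leave open whether methoxy, fluoro or hydrogen at this place makes any difference to cytotoxicity.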